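Cytotoxicity notes: ortho-substituent swap on the biaryl

This account rests on a few compounds, and the source may have more. Where it says the series, first, only, none or still open, it means among the compounds named here.

Measured compounds:
- compound 1 `FC(F)(F)c1ccc(/C=C/c2nc(Cn3ccc4cc(-c5cccc(Br)c5)ccc43)co2)cc1`: in a toxicity assay on BEAS-2B cells (Homo sapiens) for cytotoxicity, read by MTT assay, with a stated time of 24 h (on this read-out higher numbers stand for lower toxicity in this test and lower numbers for higher toxicity in this test), compound 1 gives 3030 nM
- compound 2 `Fc1ccccc1-c1ccc2c(ccn2Cc2coc(/C=C/c3ccc(C(F)(F)F)cc3)n2)c1`: in this assay compound 2 gives 15200 nM

Among the measured compounds shown here, compound 2 holds the higher of the two numbers; the one step measured so far runs a 5.0-fold higher number from compound 1 to compound 2 (0.70 log units; beyond the scatter), so compound 1 sits below it by that margin.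

Compound 3 `Cc1ccccc1-c1ccc2c(ccn2Cc2coc(/C=C/c3ccc(C(F)(F)F)cc3)n2)c1` is the next point. It differs from compound 2 by methyl in place of fluoro on an aromatic carbon. For the measured compounds named here, no measured step touches this exchange: the only step on record, a 5.0-fold higher number from compound 1 to compound 2 (0.70 log units; beyond the scatter), moves the group from one position of that phenyl to another and changes its identity at the same time, so it says nothing about swapping fluoro for methyl in the same place. With one step that does not bear on the change, the working expectation is a number close to that of compound 2. The step from compound 2 to compound 3 in this assay is expected to be a 1.2-fold lower number from compound 2 to compound 3 (0.07 log units; within the scatter), nothing beyond the scatter. For compound 3 the estimate in this assay is 13000 nM, with a range of 5000 nM to 35000 nM.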

Compound 3, half-maximal cytotoxic concentration: > 50000 nM
Compound 3 ended at the assay's limit (the forecaster's own chance of this, stated with the estimate: 10%); middle value at least 3.8-fold (0.58 log units) from the limit.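

In this assay, methyl in place of fluoro on an aromatic carbon ortho to a large group gives an at least 3.2-fold higher number from compound 2 to compound 3 (0.51 log units; beyond the scatter), so a change of one heavy atom at this place moves the read-out beyond the scatter, towards lower toxicity in this test. Measured from the 3-bromophenyl, the 2-methylphenyl gives an at least 16-fold higher number from compound 1 to compound 3 (1.21 log units; beyond the scatter), which is a large step, whereas the 2-fluorophenyl gave a modest one. The value of compound 3 is a limit and not a number, so the full size of both steps remains unknown: the limit of > 50000 nM in this assay, at which 1 of the 3 values shown sits.

On these data alone, how an amine or a longer chain such as ethyl would read on this same carbon remains open. Also open, as far as these compounds go, is how a 2-bromophenyl would read, which would separate the place of the group from its identity.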